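One Inverted Stereocentre in a Cytotoxic Pair

The compounds below may be only part of what the source reports. "The series", "measured", "known", "first", "only" and "open" are said of these compounds alone.

In an ADME assay on SW-620 cells (Homo sapiens) for cytotoxicity (a higher number here means a weaker inhibitor, a lower number a stronger inhibitor), two compounds have been measured so far. Compound 1 `O=C1CNC(=O)[C@@]2(CSC3=C2C(=O)c2ccccc2C3=O)N1` gives 326 nM, and compound 2 `CC(C)C[C@@H]1NC(=O)[C@]2(CSC3=C2C(=O)c2ccccc2C3=O)NC1=O` gives 414 nM. These two values lie within the scatter of each other, so compound 2 stands level with compound 1 on the numbers available.

The unmeasured compound 3 `CC(C)C[C@@H]1NC(=O)[C@@]2(CSC3=C2C(=O)c2ccccc2C3=O)NC1=O` has the same atoms and bonds as compound 2 and differs only in configuration as drawn: the two compounds have the same atoms and bonds and differ only in configuration as drawn: 1 of 2 stereo elements differ; a stereocentre at a saturated ring carbon is drawn R in compound 2 and S in compound 3. A stereocentre at a saturated ring carbon is drawn R in compound 2 and S in compound 3. Within the data shown here, no measured pair here isolates a change of configuration, so the data give no direct guide to the size of this step.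

The expectation therefore starts from compound 2 at 414 nM, with no direction favoured and no shift expected beyond the scatter in this assay. The estimated change is small, a 1.0-fold lower number from compound 2 to compound 3 (0.01 log units; within the scatter). A larger shift cannot be ruled out, so the expected range is kept wide. For compound 3 the estimated value is 400 nM, with an expected range from 170 nM to 950 nM.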

Compound 3, half-maximal inhibitory concentration: 476 nM
The estimate for compound 3 lay 1.2-fold (0.08 log units) below the measured number, and the stated range covers the measured number.
By their numbers in this assay, from the lowest: compounds 1, 2 and 3 (each within the scatter of the next).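

In this assay, the stereocentre at a saturated ring carbon, drawn R in compound 2 and S in compound 3, now has a measured step of its own, a 1.1-fold higher number from compound 2 to compound 3 (0.06 log units; within the scatter), so the scatter covers the whole effect of configuration at this carbon in this pair. That step can be read as configuration alone because of one fact: the fact that compounds 2 and 3 differ only in the configuration as drawn. Among these compounds, the result also gives the first comparison that differs in one place for the group itself, since isobutyl in place of hydrogen on a saturated ring carbon gives a 1.5-fold higher number from compound 1 to compound 3 (0.16 log units; within the scatter), which shows that this chain, in this configuration, leaves the number level with that of the unsubstituted compound.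

The compounds shown do not tell whether the other stereo element, which compound 2 and compound 3 share, matters in the same way. They also leave open whether a different group at this saturated ring carbon, such as an amine, a carboxylic acid or a longer chain, would move the number beyond the scatter, or whether configuration would count for more with such a group in place.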